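Ester chain change carried from one core to another

A few compounds are considered here, and "the series" means these few. Any claim that something is new, unique, unknown or untested is made for them only; others in the source may bear on it.

Two cores are followed in an assay on HEK293 cells for antagonist activity at Voltage-dependent L-type calcium channel subunit alpha-1D (Rattus norvegicus), read by FLIPR; a higher number here means a weaker inhibitor, a lower number a stronger inhibitor. Compound 1 `COC(=O)C1=C(C(C)C)NC(=O)N(C(=O)OC(C)C)C1c1cccc([N+](=O)[O-])c1` gives 10100 nM. Compound 2 `CC(C)OC(=O)C1=C(C(C)C)NC(=O)N(C(=O)OC(C)C)C1c1cccc([N+](=O)[O-])c1` gives 4310 nM; the change isopropyl in place of methyl on an oxygen next to a carbonyl group produced a 2.3-fold lower number from compound 1 to compound 2 (0.37 log units; beyond the scatter). Compound 3 `COC(=O)C1=C(C)OC(N)=C(C(=O)OC(C)C)C1c1cccc([N+](=O)[O-])c1` gives 1820 nM, the lowest of the three values; the difference between the core of compound 3 and the core of compound 1 is not broken down here. Compound 4 `CC1=C(C(=O)OC(C)C)C(c2cccc([N+](=O)[O-])c2)C(C(=O)OC(C)C)=C(N)O1` is not yet measured in this assay. It carries the same change as compound 2, (isopropyl in place of methyl on an oxygen next to a carbonyl group), at a place described in the same words. Going by the values given here, for compound 4 a step of a 2.3-fold lower number from compound 3 to compound 4 (0.36 log units; beyond the scatter) is expected, beside the earlier one, resting on a single measured pair because a 2.3-fold lower number from compound 1 to compound 2 (0.37 log units; beyond the scatter) is the only example of this change and its transfer to another core is untested. The estimate for compound 4 is 800 nM, with a range from 350 nM to 1800 nM.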

Compound 4, half-maximal inhibitory concentration: 1390 nM
Beside the measured number, compound 4's estimate is 1.7-fold (0.24 log units) below it; the measured number falls inside the stated range.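

In this assay, isopropyl in place of methyl on the oxygen next to a carbonyl group gives a 1.3-fold lower number from compound 3 to compound 4 (0.12 log units; within the scatter), so on this core the step alone cannot be told from repeat scatter. Set beside the earlier step, the two cores show no measurable difference in the size of this change: the same change on two cores in this assay, a 2.3-fold lower number (0.37 log units; beyond the scatter) from compound 1 to compound 2 and a 1.3-fold lower number (0.12 log units; within the scatter) from compound 3 to compound 4, 1.8-fold (0.25 log units) apart, within the scatter of two such steps. The data are therefore compatible with the change carrying over, but with a single pair on each core they do not show that it transfers, or that the step beyond the scatter on the core of compound 1 recurs on the core of compound 3.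

Still open, from the compounds shown here alone, is how a longer chain such as butyl, or a carboxylic acid in place of the ester, would read on either core.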